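The source may report more compounds than this note shows. Statements on the series, on what has been measured and on what is new or still open speak of the compounds shown alone.

This piece follows one change made to compound 1 `CO[C@H]1CC[C@H](Nc2cc(NCc3cnccc3C(F)(F)F)ncc2C#N)CC1`. In an assay on isolated protein for inhibition of protein kinase C theta type (Homo sapiens), read by TR-FRET, with a stated time of 2 h (on this read-out higher numbers stand for weaker inhibition and lower numbers for stronger inhibition), compound 1 gives 1100 nM. Two other compounds were measured alongside it. Compound 2 `N#Cc1cnc(NCc2ccccc2C(F)(F)F)cc1N[C@H]1C[C@@H](C(N)=O)C1` gives 150 nM in this assay, and compound 3 `N#Cc1cnc(NCc2cncnc2C(F)(F)F)cc1N[C@H]1CC[C@@H](O)CC1` gives 450 nM. Among these three numbers compound 1 stands highest, so it is the weakest inhibitor of the set: the gap to compound 3, its nearest neighbour, lies beyond the usual scatter of repeat measurements, and the gap to compound 2 is wider still.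

Compound 4 `CC1(C)[C@H](Nc2cc(NCc3cnccc3C(F)(F)F)ncc2C#N)C[C@H]1C(N)=O` has not yet been measured. It differs from compound 1 in one place: 3-carbamoyl-2,2-dimethylcyclobutyl in place of 4-methoxycyclohexyl on a nitrogen on an aromatic ring. Among the measured compounds shown here, no pair of the measured compounds differs in exactly this way, so no measured step describes the change directly. Compound 2 also carries a carbamoyl group on a cyclobutyl ring and gives 150 nM, the lowest number of the three, though it differs from compound 1 elsewhere as well, so the comparison is only a hint. On that hint the number for compound 4 is expected to fall clearly below that of compound 1, an estimated step of a 4.4-fold lower number from compound 1 to compound 4 (0.64 log units; beyond the scatter) in this assay, beyond the scatter. The estimate for compound 4 is 250 nM, with a range from 80 nM to 800 nM.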

Compound 4, half-maximal inhibitory concentration: 140 nM
Compound 4: middle estimate off by 1.8-fold (0.25 log units), on the high side, within the range that was stated.
By their numbers in this assay, from the lowest: compounds 4 and 2 (each within the scatter of the next); then compound 3; then compound 1.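

In this assay, among the compounds shown here, exchanging the one group gives a 7.9-fold lower number from compound 1 to compound 4 (0.90 log units; beyond the scatter), the first comparison here in which only this one place changes, and it shows that the number responds to the group held at this position. The step is a bundle of changes rather than a single one: a six-membered ring gives way to a four-membered ring, methoxy gives way to carbamoyl, a hydrogen-bond donor is added, and two methyl groups come in. Nothing shown here explains the stronger inhibition or assigns it to any one of those changes.

Going by these compounds, it remains open which part of the new group matters: on the core of compound 1, a cyclobutyl ring carrying the carbamoyl group without the two methyl groups would test the methyl groups, while a cyclohexyl ring carrying the carbamoyl group would test ring size. A carboxylic acid or an amine in place of the carbamoyl group, on the same dimethylcyclobutyl ring, would show how much depends on the amide itself.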